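Replacing Pentan-3-yl with 2-Methoxyphenyl: A Solubility Expectation

This account rests on a few compounds, and the source may have more. Where it says the series, first, only, none or still open, it means among the compounds named here.

Compound 1 `O=C(C1=C(O)C(=O)N(c2ccc(-c3ccon3)cc2)C1C1CCCCC1)c1ccc(CO)cc1`, compound 2 `O=C(O)c1ccc(C(=O)C2=C(O)C(=O)N(c3ccc(-c4ccon4)cc3)C2C2CCCCC2)cc1` and compound 3 `CCC(CC)C1C(C(=O)c2ccc(OC)cc2)=C(O)C(=O)N1c1ccc(-c2ccon2)cc1` share one core and were examined in a physicochemical assay for solubility, in phosphate buffer, at pH 6.8; a lower number here means a less soluble compound, a higher number a more soluble compound. In this assay compound 1 gives > 50000 nM, which is a limit of the assay and not a number. In this assay compound 2 gives > 50000 nM, again a limit. Compound 3 is the only one of the three with a measured number, giving 2200 nM in this assay. Two of the three values shown sit at the limit of > 50000 nM in this assay, at which 2 of the 3 values shown sit. For the measured compounds named here, the single measured step, a step that the two limits leave unreadable from compound 1 to compound 2, is therefore unreadable in size. Compound 4 `COc1ccc(C(=O)C2=C(O)C(=O)N(c3ccc(-c4ccon4)cc3)C2c2ccccc2OC)cc1` differs from compound 3 by 2-methoxyphenyl in place of pentan-3-yl on a saturated ring carbon. No measured step touches this change, so nothing shown argues for a shift in either direction. Compound 4 is expected to give 3000 nM, between 1000 nM and 10000 nM, the step of a 1.4-fold higher number from compound 3 to compound 4 (0.13 log units; within the scatter) being estimated to stay within the usual scatter.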

Compound 4, solubility: 34700 nM
Compound 4: middle estimate off by 12-fold (1.06 log units), on the low side, and the stated range ends below it.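

In this assay the exchange of pentan-3-yl for 2-methoxyphenyl gives a 16-fold higher number from compound 3 to compound 4 (1.20 log units; beyond the scatter), the only step shown whose size can be read. For the compounds shown here, it shows that a change of group on this saturated ring carbon can move the number well beyond the scatter, which the earlier compounds could not show. Nothing shown gives a reason for the size of this step. Whether the aromatic ring or its methoxy group accounts for the step remains open. So does how a plain phenyl or an aminophenyl group would read on this carbon.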